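Removing the Ortho Phenyl from a Proline Anilide

The compounds below may be only part of what the source reports. "The series", "measured", "known", "first", "only" and "open" are said of these compounds alone.

Compound 1 `O=C(Nc1ccccc1-c1ccccc1)[C@@H]1CCCN1C(=O)CSc1nc2ccccc2[nH]1` is the reference point of this small set. In an assay on CHO cells for displacement of a labelled ligand from Orexin/Hypocretin receptor type 1 (Homo sapiens) (a higher number here means a weaker inhibitor, a lower number a stronger inhibitor), compound 1 gives 10 nM, the lowest of the three numbers. Compound 3 `Cn1c(CCC(=O)N2CCC[C@H]2C(=O)Nc2ccccc2-c2ccccc2)nc2ccccc21` gives 15 nM in this assay, and the change a 1.5-fold higher number from compound 1 to compound 3 (0.18 log units; within the scatter) falls within the scatter. Among the measured compounds shown here, compound 2 `O=C(Nc1ccccc1-n1cccc1)[C@@H]1CCCN1C(=O)CSc1nc2ccccc2s1` gives 39 nM, a weaker inhibitor than compound 1 by a margin beyond the scatter; it differs from compound 1 in two places at once, so its number alone shows no single step.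

Compound 4 `O=C(Nc1ccccc1)[C@@H]1CCCN1C(=O)CSc1nc2ccccc2[nH]1` takes away the second aromatic ring of the anilide: hydrogen in place of phenyl on an aromatic carbon. For the measured compounds named here, no measured step bears directly on this change. Going by the values given here, the one clean step, from compound 1 to compound 3, alters the chain on the other side of the core and is within the scatter, so it says nothing about the anilide ring. Compound 2 carries a different five-membered ring in that position together with a different heterocycle on the chain, and its weaker number cannot be assigned to either change.

With no guidance from the measured pairs, and a whole aromatic ring leaving, the expectation for compound 4 is a clear loss of potency, a 30-fold higher number from compound 1 to compound 4 (1.48 log units; beyond the scatter), placing compound 4 at an estimated 300 nM in this assay, within a wide range from 50 nM to 2500 nM.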

Compound 4, inhibition constant: 1400 nM
Estimate against measurement, compound 4: 4.7-fold (0.67 log units) below; low and high end bracket the measured number.
By their numbers in this assay, from the lowest: compounds 1 and 3 (each within the scatter of the next); then compound 2; then compound 4.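

Replacing phenyl with hydrogen on the aromatic carbon of the anilide gives a 140-fold higher number from compound 1 to compound 4 (2.15 log units; beyond the scatter) in this assay. Among the compounds shown here, this is the first measured step at this position, and it is far larger than the one step known before, which lay within the scatter and changed the chain on the other side of the core. The group that leaves is a six-membered aromatic ring of carbon only, with no hydrogen-bond donors or acceptors and no net charge, yet this position proves decisive for the number in this set, and no measurement shown bears on the reason for so large a step.

The compounds shown leave open how much of the number returns with something smaller than phenyl on that carbon, such as a methyl group, a methoxy group or a chlorine atom, or with a pyridine ring in its place. On these data alone, the five-membered ring of compound 2 arrives together with a different heterocycle on the chain, so its standing against phenyl cannot be read, and whether the same large step holds with the chain of compound 3 also remains open.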